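The source may report more compounds than this note shows. Statements on the series, on what has been measured and on what is new or still open speak of the compounds shown alone.

Working notes on the series.

Compound 1, `CN(C)C(=O)c1cc2cnc(Nc3ccc(C(=O)NCCCCCN=C=S)cc3)nc2n1C1CCCC1`, gives 76.5% in a functional assay on NCI-H1299 cells (Homo sapiens) for inhibition, read by CCK-8 assay, with a stated time of 72 h, tested at 10 uM; a lower number here means a weaker effect, a higher number a stronger effect of the compound at the concentration tested. Compound 2, `CN(C)C(=O)c1cc2cnc(Nc3ccc(NC(=O)CCCN=C=S)cc3)nc2n1C1CCCC1`, gives 78.8% in this assay. Within the data shown here, the one step between measured compounds, a number 2.3 percentage points higher from compound 1 to compound 2 (within the scatter), exchanges a group of 9 heavy atoms for a group of 11 heavy atoms on an aromatic carbon and leaves the read-out where it was. Among the measured compounds shown here, compound 2 therefore stands on only two numbers, and the number of compound 1 lies within the scatter of its own, so the pair does not separate.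

Compound 3, `CN(C)C(=O)c1cc2cnc(Nc3ccc(NC(=O)CCCCCN=C=S)cc3)nc2n1C1CCCC1`, is not yet measured. It differs from compound 2 by a group of 5 heavy atoms (3 carbon, 1 nitrogen, 1 sulfur; no ring) in place of a group of 3 heavy atoms (1 carbon, 1 nitrogen, 1 sulfur; no ring), on a saturated chain carbon, three bonds along the chain from a carbonyl carbon, on a saturated chain carbon, three bonds along the chain from a carbonyl carbon: the chain that carries the isothiocyanate grows by two carbons. For the measured compounds named here, the only step that bears on this, a number 2.3 percentage points higher from compound 1 to compound 2 (within the scatter), also moved the length of that chain and stayed within the scatter, so no step beyond the scatter is expected in this assay in either direction. Compound 3 is estimated at 78%, between 66% and 88%, which means an expected step of a number 0.8 percentage points lower from compound 2 to compound 3 (within the scatter).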

Compound 3, a percentage reported as inhibition, at one concentration (the size of the read-out at that concentration, not a potency): 85%
The estimate for compound 3 lay 7 percentage points below the measured number; measured number inside the range.
By their numbers in this assay, from the lowest: compounds 1, 2 and 3 (each within the scatter of the next).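

In this assay, the longer chain carrying the isothiocyanate, a group of 5 heavy atoms in place of a group of 3 heavy atoms on a saturated chain carbon, three bonds along the chain from a carbonyl carbon, gives a number 6.2 percentage points higher from compound 2 to compound 3 (within the scatter), so this position accepts the longer chain with no step beyond the scatter. The other comparison, a number 8.5 percentage points higher from compound 1 to compound 3 (within the scatter), exchanges one group of 11 heavy atoms for another with the same atom counts on an aromatic carbon, with the amide of the linker turned around, and this change also does not separate the compounds. Nothing on hand bears on the reason for these numbers.

On these data alone, whether a longer chain than that of compound 3 would move the read-out beyond the scatter remains open, as does whether an amine or a carboxylic acid could take the place of the isothiocyanate and keep the read-out. All three numbers come from a single concentration in this assay, so the potency of these compounds also remains open.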